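Shortening the acyl chain on a metabotropic glutamate receptor 2 modulator

The source may report more compounds than this note shows. Statements on the series, on what has been measured and on what is new or still open speak of the compounds shown alone.

The series is built around a diaryl ether core carrying a carboxylic acid at one end and an acyl phenol at the other. In an assay on HEK293 cells for positive allosteric modulation of metabotropic glutamate receptor 2 (Rattus norvegicus), read by thallium flux, with a stated time of 2.5 min (a lower number here means that less compound is needed, a higher number that more compound is needed for the effect), compound 1 `COc1cc(C(=O)O)ccc1OCCCCOc1ccc(C(=O)CC(C)C)c(O)c1C` gives 40 nM, and compound 2 `CCCC(=O)c1ccc(OCCCCOc2ccc(C(=O)O)cc2C)c(C)c1O` gives 104 nM. Compound 2 thus stands at the highest of the two numbers, with compound 1 showing a lower number and the gap between them lying beyond the usual scatter. Compound 3 `CCC(=O)c1ccc(OCCCCOc2ccc(C(=O)O)cc2C)c(C)c1O` has not yet been measured. It differs from compound 2 by hydrogen in place of methyl on a saturated chain carbon, two bonds along the chain from a carbonyl carbon. For the measured compounds named here, no directly comparable pair of measured compounds separates this single change from others, so its effect cannot be read off the data. The author expects a step from compound 2 to compound 3 of about a 1.4-fold higher number from compound 2 to compound 3 (0.16 log units; within the scatter), a mild rise, if any, in this assay. Compound 3 is therefore estimated at 150 nM, with a range from 60 nM to 400 nM.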

Compound 3, half-maximal effective concentration: 82 nM
Compound 3: the middle estimate sits 1.8-fold (0.26 log units) above what was measured; the measured number falls inside the stated range.
By their numbers in this assay, from the lowest: compound 1; then compounds 3 and 2 (each within the scatter of the next).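

In this assay, for the compounds shown here, cutting the chain by one carbon, propylcarbonyl to propanoyl, gives a 1.3-fold lower number from compound 2 to compound 3 (0.10 log units; within the scatter) and so shows, for the first time, a change made in one place alone. At this chain carbon, methyl and hydrogen cannot be told apart in this assay, so the outer carbon of the propylcarbonyl chain makes no difference beyond the scatter. No measurement offered here explains this result.

The compounds shown leave open whether a longer chain, a branched chain or an acetyl group at this carbonyl would keep the number within the same scatter. Compound 1 differs from compound 2 and compound 3 in more than one place, and how much of its lower number belongs to its branched acyl chain, rather than to its methoxy group, remains unresolved.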